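The source may hold more compounds than are shown below. What is called first, only, known or untested is meant among the compounds shown, and "the series" means these compounds.

Measured so far:
compound 2 `CCCCCCCCCCCCCCN(NC(=O)COC)C(=O)OC(C)(C)C` — 40900 nM
compound 1 `CCCCCCCCCCN(NC(=O)COC)C(=O)CCCCCCCCC` — 97300 nM

In a functional assay on K562 cells (Homo sapiens) for antiproliferative activity, read by resazurin assay, with a stated time of 72 h (on this read-out higher numbers stand for weaker inhibition of growth and lower numbers for stronger inhibition of growth), compound 2 gives the lower of the two numbers, and compound 1 sits beyond the usual scatter above it. Compound 3 `CCCCCCCCCCN(NC(=O)COC)C(=O)OC(C)(C)C` has not been measured; it differs from compound 2 by hydrogen in place of butyl on a saturated chain carbon, ten or more bonds along the chain from an amide-type nitrogen. Going by the values given here, no single-change step between measured compounds exists to calibrate this change, so only a modest step is expected, leaning toward weaker inhibition of growth. The expected step is a 1.5-fold higher number from compound 2 to compound 3 (0.17 log units; within the scatter). Compound 3 is estimated at 60000 nM, within a range from 25000 nM to 150000 nM.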

Compound 3, concentration for 50% growth inhibition: 40600 nM
Estimate against measurement, compound 3: 1.5-fold (0.17 log units) above, and the stated range covers the measured number.
By their numbers in this assay, from the lowest: compounds 3 and 2 (each within the scatter of the next); then compound 1.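

In this assay, hydrogen in place of butyl on a saturated chain carbon, ten or more bonds along the chain from an amide-type nitrogen, gives a 1.0-fold lower number from compound 2 to compound 3 (0.00 log units; within the scatter) and so does not separate these two chains. Tert-butoxy in place of nonyl on a carbonyl carbon gives a 2.4-fold lower number from compound 1 to compound 3 (0.38 log units; beyond the scatter) and is the only single change shown that goes beyond the scatter. No evidence on the cause of either step is available. The compounds shown leave open whether an amine or a carboxylic acid in that chain place would change the number, and whether a much shorter chain would.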